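The source may report more compounds than this note shows. Statements on the series, on what has been measured and on what is new or still open speak of the compounds shown alone.

The measured compounds:

compound 1 `COc1cc(-c2nccn2C)cc(OC)c1OC` — in a functional assay on T47D cells (Homo sapiens) for antiproliferative activity, read by MTT assay, with a stated time of 72 h (a lower number here means a stronger inhibitor, a higher number a weaker inhibitor), compound 1 gives a limit of the assay, > 100000 nM
compound 2 `COc1cc(-c2nccn2CC(C)C)cc(OC)c1OC` — in this assay compound 2 gives a limit of the assay, > 100000 nM

For the measured compounds named here, compound 1 thus stands at the edge of what this assay can report: it gives no number, only a limit, and the one other value shown is a limit as well. Going by the values given here, the single measured step, a step that the two limits leave unreadable from compound 1 to compound 2, cannot be sized because the limit of > 100000 nM in this assay, at which 2 of the 2 values shown sit, hides any difference between the two compounds.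

Compound 3 `COc1cc(-c2nccn2-c2cccc(C)c2)cc(OC)c1OC` is the next compound, built from compound 1 by 3-methylphenyl in place of methyl on an aromatic nitrogen. Among the compounds with values here, no measured step touches this group or this position; the only step known changes a different part of the core and is itself unreadable. What the two measured compounds show is that the shared core with a small group on the aromatic nitrogen reaches no measurable inhibition in this assay. On that basis compound 3 is expected to stay near the same limit, with the step of a number no higher from compound 1 to compound 3 (the limit leaves the size open) estimated as none beyond the scatter. The estimate for compound 3 in this assay is 100000 nM, in a range from 20000 nM to 300000 nM.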

Compound 3, half-maximal inhibitory concentration: 29300 nM
Compound 3: the middle estimate sits 3.4-fold (0.53 log units) above what was measured; the range from low to high includes it.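

In this assay, for the compounds shown here, 3-methylphenyl on the aromatic nitrogen gives the first value in this set that is a true number rather than a limit, with an at least 3.4-fold lower number from compound 1 to compound 3 (0.53 log units; beyond the scatter) and an at least 3.4-fold lower number from compound 2 to compound 3 (0.53 log units; beyond the scatter). Both steps are minimum sizes, and the real gaps could be larger, because the two starting compounds give no number: the limit of > 100000 nM in this assay, at which 2 of the 3 values shown sit. Compound 2 shows that the isobutyl chain does not bring a readable value at this position, whereas compound 3, with its six-membered aromatic ring of carbon only, does, so this position can respond to a change, though not to every larger group.

The compounds shown cannot separate the contribution of the ring from that of its methyl, and plain phenyl on the same nitrogen would be the direct comparison. As far as these compounds go, it also remains open whether a saturated ring such as cyclohexyl, or a phenyl ring carrying a chlorine or a methoxy group instead of the methyl, would give a lower or a higher number than compound 3.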